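Removing the piperazine methyl: compound 3 to compound 4

A few compounds are considered here, and "the series" means these few. Any claim that something is new, unique, unknown or untested is made for them only; others in the source may bear on it.

Compound 1, `COc1cc(Br)c(S(=O)(=O)Nc2ccc(C(F)(F)F)c(O[C@@H]3CCN(C)C3)c2)cc1OC`, gives 34 nM in a functional assay on CHO-K1 cells for antagonist activity at Urotensin-2 receptor (Rattus norvegicus), read by FLIPR and calcium flux, with a stated time of 1 h; a lower number here means a stronger inhibitor, a higher number a weaker inhibitor.
Compound 2, `COc1ccc([C@@H](CCCN(C)S(=O)(=O)c2cccs2)N2Cc3c(cccc3N3CCN(C4CC4)CC3)C2=O)cc1OC`, gives 13 nM in this assay.
Compound 3, `COc1ccc([C@@H](CCCN(C)S(=O)(=O)c2cccs2)N2Cc3c(cccc3N3CCN(C)CC3)C2=O)cc1OC`, gives 16 nM in this assay.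

Compound 3 stands second highest of these three numbers. Its nearest neighbour is compound 2, and the step of a 1.2-fold higher number from compound 2 to compound 3 (0.09 log units; within the scatter) is within the scatter, so the two cannot be ordered. Compound 1 is the furthest from it, with a higher number that lies beyond the scatter.

Compound 4, `COc1ccc([C@@H](CCCN(C)S(=O)(=O)c2cccs2)N2Cc3c(cccc3N3CCNCC3)C2=O)cc1OC`, has not yet been measured. It differs from compound 3 by hydrogen in place of methyl on an amine nitrogen in a ring. Within the data shown here, the one measured step that bears on this position is the change from compound 2 to compound 3, cyclopropyl to methyl on the same ring nitrogen, which moved the number only within the scatter. Nothing measured speaks to loss of the last carbon on that nitrogen, so the expectation rests on that single step alone. On that basis no step beyond the scatter is expected in this assay, and the estimated step is a 1.3-fold higher number from compound 3 to compound 4 (0.10 log units; within the scatter). Compound 4 is therefore expected to give about 20 nM, with a range from 8 nM to 50 nM.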

Compound 4, half-maximal inhibitory concentration: 39 nM
Compound 4: middle estimate off by 2.0-fold (0.29 log units), on the low side; low and high end bracket the measured number.
By their numbers in this assay, from the lowest: compounds 2 and 3 (each within the scatter of the next); then compounds 1 and 4 (each within the scatter of the next).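

In this assay, the group on this ring nitrogen proves to matter once no carbon is left on it: hydrogen in place of methyl gives a 2.4-fold higher number from compound 3 to compound 4 (0.39 log units; beyond the scatter) and hydrogen in place of cyclopropyl gives a 3.0-fold higher number from compound 2 to compound 4 (0.48 log units; beyond the scatter) on the same shared core. The earlier pair could show only that methyl and cyclopropyl at this place cannot be ordered, with a 1.2-fold higher number from compound 2 to compound 3 (0.09 log units; within the scatter) as their step, and so gave no sign that this nitrogen was sensitive to any change. Among these three compounds, the two with a carbon group on the nitrogen therefore stand together, while the one with the free piperazin-1-yl group has the higher number, though nothing available accounts for this step.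

What the compounds shown leave open is how far the tolerance for carbon groups on this nitrogen extends, for example whether an ethyl, isopropyl or benzyl group would stay with compound 2 and compound 3. They also leave open whether a group joined through a carbonyl, such as acetyl, or a chain ending in a hydroxyl would behave like those carbon groups or like the hydrogen of compound 4.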